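Opening the Ring on the Amide Nitrogen

The source may hold more compounds than are shown below. What is called first, only, known or untested is meant among the compounds shown, and "the series" means these compounds.

Of the compounds shown here, two that share one core have been measured in an assay on cell membranes for displacement of a labelled ligand from Cholecystokinin receptor type A (Rattus norvegicus), read by CCK-8 assay, with a stated time of 2 h; a higher number here means a weaker inhibitor, a lower number a stronger inhibitor. Compound 1 `O=C1C=C(Cl)C(O)(c2ccccc2)N1C1CC1` carries a cyclopropyl group on the amide-type nitrogen of the ring, and in this assay compound 1 gives 7500 nM. Compound 2 `O=C1C=C(Cl)C(O)(c2ccccc2)N1C1CCCC1` carries a cyclopentyl group in the same place, and in this assay compound 2 gives 360 nM. Within the data shown here, the step of a 21-fold lower number from compound 1 to compound 2 (1.32 log units; beyond the scatter) is the only one recorded so far, and among the two numbers available compound 2 stands at the lower end, with compound 1 as its only neighbour. Compound 3 `CC(C)CN1C(=O)C=C(Cl)C1(O)c1ccccc1` is the next compound; its change from compound 2 is isobutyl in place of cyclopentyl on an amide-type nitrogen in a ring. Among the measured compounds shown here, the single measured step bears on this only loosely: it showed that going from a small ring to a larger ring on this nitrogen gave a much lower number, whereas isobutyl is a branched chain with no ring. A modest rise in the number is therefore expected, a 2.2-fold higher number from compound 2 to compound 3 (0.35 log units; beyond the scatter), though it could stay within the scatter. For compound 3 the estimate in this assay is 800 nM, with a range from 200 nM to 4000 nM.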

Compound 3, half-maximal inhibitory concentration: 20 nM
The estimate for compound 3 lay 40-fold (1.60 log units) above the measured number; the measured number lies below the stated range.
By their numbers in this assay, from the lowest: compound 3; then compound 2; then compound 1.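

In this assay the open-chain isobutyl group in place of cyclopentyl on the amide-type nitrogen gives an 18-fold lower number from compound 2 to compound 3 (1.26 log units; beyond the scatter) and so shows that a ring on this nitrogen is not needed for a low number. Set against cyclopropyl, the same group gives a 380-fold lower number from compound 1 to compound 3 (2.57 log units; beyond the scatter) and places compound 3 lowest of the three, so heavy-atom count alone does not set the order: the first step paired a larger ring with a lower number, yet compound 3 goes against that pattern, with 4 heavy atoms in its isobutyl against 5 in the cyclopentyl of compound 2. Among these compounds, no measurement on hand explains why this change lowers the number so far.

The compounds shown leave open whether the low number belongs to the branch in isobutyl or to an open chain as such, which a straight butyl chain or a longer branched chain on this nitrogen could help to separate. They also leave open how a cyclohexyl ring or a chain ending in an amine would compare at this position, and whether the isobutyl result holds when the phenyl or chloro group is changed.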